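From 4-aminophenyl to 4-hydroxyphenyl: a start without a number

The source may report more compounds than this note shows. Statements on the series, on what has been measured and on what is new or still open speak of the compounds shown alone.

Compound 1, `COC(=O)c1c(-c2ccc(Br)cc2)oc2ccccc2c1=O`, and compound 2, `COC(=O)c1c(-c2ccc(N)cc2)oc2ccccc2c1=O`, share one core and differ in a single group. In a functional assay on Malme-3M cells (Homo sapiens) for cytotoxicity, read by MTT assay, with a stated time of 6 days (a higher number here means that more compound is needed for the effect, a lower number that less compound is needed), compound 1 gives > 25 ug/mL, which is a limit of the assay and not a number. In this assay compound 2 gives > 25 ug/mL, which is again only a limit. Compound 2 thus stands at the limit of > 25 ug/mL in this assay, at which 2 of the 2 values shown sit, and offers no number from which to measure a change.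

Compound 3, `COC(=O)c1c(-c2ccc(O)cc2)oc2ccccc2c1=O`, carries hydroxy in place of amino on an aromatic carbon, para to a large group: hydroxy in place of amino on an aromatic carbon. Within the data shown here, the only measured step that bears on this change is a step that the two limits leave unreadable from compound 1 to compound 2, and it replaced bromo with amino on an aromatic carbon. That step gives no size to carry over, so no step beyond the scatter is expected in this assay, and no direction is favoured. The expected change is a step that the limit leaves unreadable from compound 2 to compound 3. A limit is the likeliest report, but if a number appears, the estimated concentration for half-maximal effect of compound 3 is 28 ug/mL, within an expected range of 12 ug/mL to 60 ug/mL.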

Compound 3, concentration for half-maximal effect: > 25 ug/mL
Compound 3 gave a limit, no number; the forecaster's own chance of this, stated with the estimate: 75%; the middle value does not contradict the limit.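

In this assay compound 3 gives > 25 ug/mL, which is a limit of the assay and not a number. No step between compound 1, compound 2 and compound 3 can therefore be read: the limit of > 25 ug/mL in this assay, at which 3 of the 3 values shown sit.

The compounds shown leave open how bromo, amino and hydroxy compare in this assay, and whether any group at this place gives a number at all.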